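Amide to Sulfonamide: Cytotoxicity Outlook for Compound 3

The source may hold more compounds than are shown below. What is called first, only, known or untested is meant among the compounds shown, and "the series" means these compounds.

Compound 1 `O=C(Nc1ncc(C(Oc2ccc3cc(Br)ccc3c2)c2ccc(Cl)cc2)s1)c1ccc(Br)cc1`: > 50000 nM
Compound 2 `O=C(Nc1ncc(C(Oc2ccc3cc(Br)ccc3c2)c2ccc(Cl)cc2)s1)c1ccc(F)cc1Br`: > 50000 nM

In an ADME assay on HepG2 2.2.15 cells (Homo sapiens) for cytotoxicity (a higher number here means that more compound is tolerated, a lower number that less compound is tolerated), compound 2 gives > 50000 nM, which is a limit of the assay rather than a measured number. Compound 1 likewise gives > 50000 nM, again a limit. Both values sit at the same limit, so the step that the two limits leave unreadable from compound 1 to compound 2 cannot be read, and nothing can be said about its size. This is the whole picture: the limit of > 50000 nM in this assay, at which 2 of the 2 values shown sit.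

Compound 3 `O=S(=O)(Nc1ncc(C(Oc2ccc3cc(Br)ccc3c2)c2ccc(Cl)cc2)s1)c1cccs1` differs from compound 2 by (thiophen-2-yl)sulfonyl in place of (2-bromo-4-fluorophenyl)carbonyl on a nitrogen on an aromatic ring. Going by the values given here, no measured step covers a change of this kind, and the one measured step is unreadable. Among the compounds with values here, the only guide is that both measured compounds were tolerated up to the limit. The change is expected to amount to a step that the limit leaves unreadable from compound 2 to compound 3, that is, no readable shift. Compound 3 is therefore expected near 60000 nM, within 20000 nM to 200000 nM, most likely reported again only as a limit.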

Compound 3, half-maximal cytotoxic concentration: "not toxic" (no number reported)
Compound 3: no number reported; no gap can be computed for the estimate.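

Compound 3 is reported in this assay only as "not toxic", without a number, so no new step can be read from compound 2 or compound 1 to compound 3. The compounds shown leave open how much of any of the three is actually tolerated, because the only values given stop at one limit: the limit of > 50000 nM in this assay, at which 2 of the 3 values shown sit.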